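Halogen swap on a weak xanthine-type series

The compounds below may be only part of what the source reports. "The series", "measured", "known", "first", "only" and "open" are said of these compounds alone.

Measured so far:
compound 1, `Cn1c(=O)c2c(nc(CCSc3cccc(Cl)c3)n2C)n(C)c1=O`, "not active" (no number reported)
compound 2, `Cn1c(=O)c2c(nc(COc3cccc(Br)c3)n2C)n(C)c1=O`, 34000 nM

Compound 2, `Cn1c(=O)c2c(nc(COc3cccc(Br)c3)n2C)n(C)c1=O`, carries the only number shown so far; in an in vitro assay on cells for inhibition of Amine oxidase [flavin-containing] A (Homo sapiens), read by coupled enzyme assay, with a stated time of 20 min (a lower number here means a stronger inhibitor, a higher number a weaker inhibitor), compound 2 gives 34000 nM. Compound 1, `Cn1c(=O)c2c(nc(CCSc3cccc(Cl)c3)n2C)n(C)c1=O`, was reported as inactive without a number, so no comparison between the two can be drawn.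

Compound 3, `Cn1c(=O)c2c(nc(COc3cccc(Cl)c3)n2C)n(C)c1=O`, differs from compound 2 by chloro in place of bromo on an aromatic carbon.

Going by the values given here, no measured pair shows the size of such a change. The step from compound 2 to compound 3 is expected to be small, a 1.3-fold higher number from compound 2 to compound 3 (0.12 log units; within the scatter), within the scatter or at most a modest weakening. Compound 3 is therefore estimated at 45000 nM, between 15000 nM and 150000 nM.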

Compound 3, half-maximal inhibitory concentration: "not active" (no number reported)
For compound 3 the study gives words and no number, and the estimate cannot be compared.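

Going by these compounds alone, with compound 3 given only as inactive and no number, no step from compound 2 can be read in this assay here. The compounds shown leave open how far 3-bromophenyl to 3-chlorophenyl shifts inhibition. No supporting evidence bears on this result.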